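Swapping a Sulfanyl for an Amino on a Small Core

A few compounds are considered here, and "the series" means these few. Any claim that something is new, unique, unknown or untested is made for them only; others in the source may bear on it.

Measured so far:
Compound 1, `Sc1[nH]ccc2ncnc1-2`: 26%
Compound 2, `OC[C@H]1O[C@@H](n2cnc3c(S)nccc32)C[C@@H]1O`: 10%

Of the compounds shown here, two have been measured in a functional assay (Homo sapiens) for inhibition of Nucleic Acid, tested at 100 uM; on this read-out lower numbers stand for less inhibition and higher numbers for more inhibition at the one concentration tested (going by the name of the read-out). Compound 1, with the structure `Sc1[nH]ccc2ncnc1-2`, gives 26%. Compound 2, with the structure `OC[C@H]1O[C@@H](n2cnc3c(S)nccc32)C[C@@H]1O`, gives 10%. Compound 1 thus has the higher of the two numbers, and the gap to compound 2 is beyond the usual scatter of this read-out. Compound 2 carries a sugar-like attachment that compound 1 lacks, and since no single-point step between the two is shown, only their two values can be compared.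

The next compound, compound 3, has the structure `Nc1[nH]ccc2ncnc1-2`. It differs from compound 1 in one place: amino in place of sulfanyl on an aromatic carbon. Both groups bring one heavy atom and one hydrogen-bond donor and one acceptor, so the change is small in size. Among the measured compounds shown here, with no measured step to lean on, the expected move from compound 1 to compound 3 in this assay is a number 8 percentage points lower from compound 1 to compound 3 (within the scatter), a small drop that may well sit within the scatter. Compound 3 is therefore estimated at 18%, with a likely range from 0% to 38%.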

Compound 3, a percentage reported as inhibition, at one concentration (the size of the read-out at that concentration, not a potency): 60%
Beside the measured number, compound 3's estimate is 42 percentage points below it; measured number outside the range, above it.
By their numbers in this assay, from the lowest: compound 2; then compound 1; then compound 3.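

Putting amino in place of sulfanyl on an aromatic carbon next to the ring nitrogen gives, in this assay, a number 34 percentage points higher from compound 1 to compound 3 (beyond the scatter). Among the compounds shown here, this is the first change in the set made in a single place, and it shows that the read-out responds strongly to the group on this carbon. The two groups have the same counts of heavy atoms, hydrogen-bond donors and hydrogen-bond acceptors and neither carries a net charge, so those counts alone do not predict the result at this position, and nothing measured here accounts for the difference between sulfanyl and amino.

On these data alone, it remains open whether the same swap would also raise the number for the sugar-bearing compound 2, and how a hydroxyl, a methylamino group or a longer chain on this carbon would compare with amino. As far as these compounds go, each compound also has a reading at only one concentration, so the ranking by potency remains open too.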